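This account rests on a few compounds, and the source may have more. Where it says the series, first, only, none or still open, it means among the compounds named here.

Notes on the series. Three compounds share the core carried by compound 3 `O=C(O)c1cc(F)c2nc(N3CCC4(C=C(c5c(-c6c(Cl)cccc6Cl)noc5C5CC5)C4)CC3)sc2c1`. For the measured compounds named here, compound 1 `O=C(O)c1cc(F)c2nc(N3CCC4(CC3)OCC(c3c(-c5c(Cl)cccc5Cl)noc3C3CC3)O4)sc2c1` belongs to the same set, but the only entry for compound 1 is "not determined" (no result reported). Compound 2 `O=C(O)c1cc(F)c2nc(N3CCC4(CC3)COC(c3c(-c5c(Cl)cccc5Cl)noc3C3CC3)O4)sc2c1` belongs to it too, and the entry for compound 2 is likewise "not determined" (no result reported), so no numbers can be compared across them. The read-out throughout is an assay on isolated protein for agonist activity at Bile acid receptor (Homo sapiens), with a stated time of 30 min; on this read-out higher numbers stand for an effect only at larger amounts of compound and lower numbers for an effect already at smaller amounts. In this assay, going by the values given here, compound 3 gives 62.2 nM, which is the only number obtained in the set; it therefore stands alone, with no second measured compound to rank it against, and no step between measured compounds can be stated.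

The next compound, compound 4 `O=C(O)c1cc(F)c2nc(N3CCC4(C=C(c5c(-c6c(Cl)cncc6Cl)noc5C5CC5)C4)CC3)sc2c1`, differs from compound 3 in a single place: 3,5-dichloropyridin-4-yl in place of 2,6-dichlorophenyl on an aromatic carbon. Everything else in the molecule stays as in compound 3, so any change in the read-out would be tied to this exchange alone. Among the compounds with values here, with no measured pair in the set that carries a comparable exchange, the expectation rests on the single value of compound 3 62.2 nM and the size of the change, which is small in heavy-atom count. The step from compound 3 to compound 4 is expected to be a 1.5-fold higher number from compound 3 to compound 4 (0.18 log units; within the scatter), a mild shift toward weaker activity that may not clear the usual scatter. Compound 4 is therefore estimated at 95 nM, within a range from 35 nM to 280 nM.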

Compound 4, half-maximal effective concentration: 187 nM
Compound 4: the middle estimate sits 2.0-fold (0.29 log units) below what was measured; the measured number falls inside the stated range.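

For the compounds shown here, the exchange of 2,6-dichlorophenyl for 3,5-dichloropyridin-4-yl gives the first readable step: in this assay the change is a 3.0-fold higher number from compound 3 to compound 4 (0.48 log units; beyond the scatter) and it shows that this aromatic carbon of the five-membered ring, next to the ring nitrogen, is sensitive to the make-up of the aryl ring it carries. The entering ring has a ring nitrogen and a hydrogen-bond acceptor that the leaving ring lacks, and the two groups match in heavy-atom count, so a change in ring composition alone is enough to move the read-out past the usual scatter, while compound 4 still gives a measurable 187 nM in this assay. Nothing available on this pair accounts for the weaker value, and the step stands as an observation only.

A single exchange cannot show whether other aryl groups at this place, such as plain phenyl or a phenyl ring bearing methoxy or trifluoromethyl groups, would hold or lose activity, nor whether tert-butyl in place of the cyclopropyl group would change the picture. As far as these compounds go, the steps from compound 1 and compound 2 to the other compounds cannot be read, so the contribution of the linking part of the molecule also stays open.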